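The compounds below may be only part of what the source reports. "The series", "measured", "known", "first", "only" and "open" are said of these compounds alone.

Within the data shown here, compound 2 `CCCn1c(=O)[nH]c2nc(-c3ccc(S(=O)(=O)N4CCN(Cc5ccc(Br)cc5)CC4)cc3)[nH]c2c1=O` is one of two compounds tested so far in an assay on CHO cells for displacement of a labelled ligand from adenosine receptor A1 (Homo sapiens), read by scintillation counting, with a stated time of 90 min, tested at 1 uM, in the presence of a further agent that is not named here; a higher number here means more inhibition at the concentration tested (going by the name of the read-out), a lower number less inhibition; here compound 2 gives 31%. Among the measured compounds shown here, the only comparison is compound 1 `CCCn1c(=O)[nH]c2nc(-c3ccc(S(=O)(=O)N4CCN(c5cccc(Cl)c5)CC4)cc3)[nH]c2c1=O`, which in this assay gives 21%. The two share everything but the group on the amine nitrogen in the ring, and the step of a number 10 percentage points higher from compound 1 to compound 2 (within the scatter) falls inside the usual scatter of repeated measurements, so the two numbers cannot be told apart with confidence, and compound 2 does not stand apart from compound 1.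

The next compound, compound 3 `CCCn1c(=O)[nH]c2nc(-c3ccc(S(=O)(=O)N4CCN(c5ccccc5Cl)CC4)cc3)[nH]c2c1=O`, changes the same position again: 2-chlorophenyl in place of 4-bromobenzyl on an amine nitrogen in a ring. For the measured compounds named here, the one measured step that bears on this change is the swap on that ring nitrogen from compound 1 to compound 2, which stayed within the scatter. With one such step, and both groups being single aromatic rings carrying one halogen, there is no basis to expect a shift beyond the scatter in this assay in either direction. The number for compound 3 is therefore estimated at 24%, with a likely range from 8% to 42%, which means an expected step of a number 7 percentage points lower from compound 2 to compound 3 (within the scatter).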

Compound 3, a percentage reported as inhibition, at one concentration (the size of the read-out at that concentration, not a potency): 25%
Beside the measured number, compound 3's estimate is 1 percentage points below it; low and high end bracket the measured number.
By their numbers in this assay, from the lowest: compounds 1, 3 and 2 (each within the scatter of the next).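

In this assay, putting 2-chlorophenyl in place of 4-bromobenzyl on the ring nitrogen gives a number 6 percentage points lower from compound 2 to compound 3 (within the scatter), so a second, different swap at this position also stays inside the usual scatter. The comparison with compound 1 adds something new, as it changes only where the chlorine sits on the phenyl ring, and 2-chlorophenyl in place of 3-chlorophenyl gives a number 4 percentage points higher from compound 1 to compound 3 (within the scatter), so these two placements of the chlorine cannot be told apart in this assay. All three groups tried on this nitrogen, with or without the extra carbon of the benzyl group, therefore give numbers that cannot be separated with confidence, and no supporting measurement is available to explain these results.

The compounds shown all carry a halogen-bearing aromatic ring on this nitrogen, so it remains open whether an unsubstituted phenyl, a pyridine, a simple alkyl chain or a group holding an amine or a carboxylic acid would give a number clearly different from these. On these data alone, it also remains open whether a change elsewhere, such as replacing the propyl chain on the shared core, would move the number beyond the scatter.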